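Swapping Bromine for Iodine on the Phenoxy Ring

This account rests on a few compounds, and the source may have more. Where it says the series, first, only, none or still open, it means among the compounds named here.

For the measured compounds named here, compound 2 `N[C@@H](COP(=O)(O)OCCCOC(=O)CCc1ccccc1OCc1cccc(Oc2ccc(Br)cc2)c1)C(=O)O` gives 17.7% in an assay on cells for agonist activity at probable G-protein coupled receptor 34 (Mus musculus), with a stated time of 1 h (on this read-out higher numbers stand for larger maximal responses and lower numbers for smaller maximal responses), and compound 1 `N[C@@H](COP(=O)(O)OCCCOC(=O)CCc1ccccc1OCc1cccc(Oc2ccc(Cl)c(Cl)c2)c1)C(=O)O`, the only other compound measured, sits within the scatter of it at 18%. Going by the values given here, the single measured step, a number 0.3 percentage points lower from compound 1 to compound 2 (within the scatter), exchanged one halogen pattern for another without leaving the scatter. Compound 3 `N[C@@H](COP(=O)(O)OCCCOC(=O)CCc1ccccc1OCc1cccc(Oc2ccc(I)cc2)c1)C(=O)O` differs from compound 2 by iodo in place of bromo on an aromatic carbon. Because the earlier halogen exchange a number 0.3 percentage points lower from compound 1 to compound 2 (within the scatter) stayed within the scatter, the expected step of a number 0.3 percentage points higher from compound 2 to compound 3 (within the scatter) is likewise none beyond the scatter. Compound 3 is therefore estimated at 18%, with a range from 8% to 30%.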

Compound 3, largest response reached (Emax), in percent of the reference or control that the assay uses: 19.1%
The estimate for compound 3 lay 1.1 percentage points below the measured number, and the stated range covers the measured number.
By their numbers in this assay, from the lowest: compounds 2, 1 and 3 (each within the scatter of the next).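

In this assay, iodo on this aromatic carbon reads the same as bromo, with a number 1.4 percentage points higher from compound 2 to compound 3 (within the scatter), and the 4-iodophenyl group reads the same as the 3,4-dichlorophenyl group, with a number 1.1 percentage points higher from compound 1 to compound 3 (within the scatter). All three halogen patterns therefore sit within the scatter of one another, and none can be ranked above another. Nothing available here accounts for this result. Still open, as far as these compounds go, is whether the response stays at this level with a group other than a halogen on this carbon, such as an amine or a carboxylic acid.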